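The source may hold more compounds than are shown below. What is called first, only, known or untested is meant among the compounds shown, and "the series" means these compounds.

Measured compounds:
Compound 1 `O=C(/C=C/c1ccc(O)c(O)c1)N1CCN(c2cccc(Cl)c2)CC1` gives 1.34 ug/mL in a functional assay on MCF7 cells (Homo sapiens) for antiproliferative activity, read by MTT assay, with a stated time of 48 h; on this read-out higher numbers stand for weaker inhibition and lower numbers for stronger inhibition.
Compound 2 `COc1ccccc1N1CCN(C(=O)/C=C/c2ccc(O)c(O)c2)CC1` gives 0.54 ug/mL.
Compound 3 `O=C(/C=C/c1ccc(O)c(O)c1)N1CCN(c2ccc(Cl)c(Cl)c2)CC1` gives 1.28 ug/mL.

Compound 1 stands highest of the three numbers, though its gap to compound 3 is within the scatter: a 1.0-fold lower number from compound 1 to compound 3 (0.02 log units; within the scatter). Its gap to compound 2 is beyond the scatter: a 2.5-fold lower number from compound 1 to compound 2 (0.39 log units; beyond the scatter).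

Compound 4 `CCN1CCN(C(=O)/C=C/c2ccc(O)c(O)c2)CC1` has not yet been measured. It differs from compound 1 in one place: ethyl in place of 3-chlorophenyl on an amine nitrogen in a ring.

The measured steps bear on this only loosely. Swapping one aromatic group on the ring nitrogen for another moved the number modestly, as in a 2.5-fold lower number from compound 1 to compound 2 (0.39 log units; beyond the scatter) and a 2.4-fold higher number from compound 2 to compound 3 (0.37 log units; beyond the scatter), while adding a chloro on that aromatic ring changed nothing beyond the scatter. For the measured compounds named here, no measured step replaces the aromatic group with a chain, so the expectation is wide. A modest rise in the number, or no step beyond the scatter, seems most likely.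

Compound 4 is therefore expected to give about 2.5 ug/mL, within a range of 0.8 ug/mL to 8 ug/mL, which means an expected step of a 1.9-fold higher number from compound 1 to compound 4 (0.27 log units; within the scatter).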

Compound 4, half-maximal inhibitory concentration: 2.06 ug/mL
Compound 4: middle estimate off by 1.2-fold (0.08 log units), on the high side; the measured number falls inside the stated range.
By their numbers in this assay, from the lowest: compound 2; then compounds 3, 1 and 4 (each within the scatter of the next).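

The swap of an aromatic group for a small chain on this ring nitrogen appears here for the first time: in this assay, ethyl in place of 3-chlorophenyl gives a 1.5-fold higher number from compound 1 to compound 4 (0.19 log units; within the scatter) and ethyl in place of 3,4-dichlorophenyl gives a 1.6-fold higher number from compound 3 to compound 4 (0.21 log units; within the scatter) so among these three compounds the aromatic ring can go without a step beyond the scatter. Only ethyl in place of 2-methoxyphenyl gives a step beyond the scatter, with a 3.8-fold higher number from compound 2 to compound 4 (0.58 log units; beyond the scatter) so the 2-methoxyphenyl compound alone stands apart among the four. No measurement shown here explains these results.

On these data alone, it remains open where a longer chain such as butyl, a benzyl group or a plain hydrogen on this nitrogen would fall. As far as these compounds go, an unsubstituted phenyl group is also absent, so the separate contribution of the methoxy group to the lower number of compound 2 stays unknown.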